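The compounds below may be only part of what the source reports. "The series", "measured", "known", "first", "only" and "open" are said of these compounds alone.

Compound 3, `C=C(C(=O)c1ccc(OC)cc1)C(OC(=O)c1ccccc1)c1ccccc1F`, is an ester in a series of three measured compounds. In a functional assay on A549 cells (Homo sapiens) for inhibition, read by XTT assay, with a stated time of 48 h (on this read-out higher numbers stand for weaker inhibition and lower numbers for stronger inhibition), compound 3 gives 73700 nM. Compound 1, `COc1ccc(C(=O)/C(=C/c2ccc(Cl)cc2)CC(C)OC(C)=O)cc1`, gives 73200 nM in this assay, and compound 2, `C=C(C(=O)c1ccc(OC)cc1)C(OC(C)=O)c1ccccc1F`, gives 67300 nM; the three numbers sit within the scatter of one another, so no order among them can be read.

Compound 4, `C=C(C(=O)c1ccc(OC)cc1)C(OC(=O)c1ccccc1)c1ccc([N+](=O)[O-])cc1`, differs from compound 3 in one place: 4-nitrophenyl in place of 2-fluorophenyl on a saturated chain carbon bound to a double-bonded chain carbon and an oxygen next to a carbonyl group. For the measured compounds named here, the only measured step, a 1.1-fold higher number from compound 2 to compound 3 (0.04 log units; within the scatter), exchanged the acyl part of the ester and left the aryl group untouched, so it does not bear directly on this change. Going by the values given here, no measured pair shows what the aryl group on that saturated chain carbon does to the read-out. With nothing in the data pointing either way, the expected step of a 1.1-fold lower number from compound 3 to compound 4 (0.02 log units; within the scatter) is none beyond the scatter. Compound 4 is therefore estimated at 70000 nM in this assay, within a range from 30000 nM to 160000 nM.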

Compound 4, half-maximal inhibitory concentration: 66600 nM
Compound 4: the middle estimate sits 1.1-fold (0.02 log units) above what was measured, and the stated range covers the measured number.
By their numbers in this assay, from the lowest: compounds 4, 2, 1 and 3 (each within the scatter of the next).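

In this assay, replacing 2-fluorophenyl with 4-nitrophenyl on the saturated chain carbon bound to a double-bonded chain carbon and an oxygen next to a carbonyl group gives a 1.1-fold lower number from compound 3 to compound 4 (0.04 log units; within the scatter). For the compounds shown here, this is the first measured pair to vary the aryl group at this position, and it shows that this exchange, which brings in two more heavy atoms and two hydrogen-bond acceptors, leaves the read-out unchanged within the scatter while the phenyl on the carbonyl carbon stays fixed. Nothing available explains this result.

On these data alone, whether a group of another kind at this position, such as 4-aminophenyl, a carboxylic acid or a longer alkyl chain, would shift the read-out remains open. As far as these compounds go, it is also open whether the same aryl exchange would behave alike with methyl on the carbonyl carbon.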